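Replacing a fluorophenyl by a thiophene on a shared core

The source may report more compounds than this note shows. Statements on the series, on what has been measured and on what is new or still open speak of the compounds shown alone.

Three compounds share one core and differ only in the group attached to it. Compound 1 `Brc1cn2ccnc2c(-c2ccc3ncn(C4CCCCC4)c3c2)n1` carries a bromo there, and in a functional assay on NCI-H23 cells (Homo sapiens) for inhibition, read by sulforhodamine B assay, with a stated time of 48 h, tested at 10 uM (a higher number here means more inhibition at the concentration tested (going by the name of the read-out), a lower number less inhibition), compound 1 gives 10.2%. Compound 2 `Fc1ccc(-c2cn3ccnc3c(-c3ccc4ncn(C5CCCCC5)c4c3)n2)cc1` carries a 4-fluorophenyl and gives 2.36%, while compound 3 `c1cn2cc(-c3ccsc3)nc(-c3ccc4ncn(C5CCCCC5)c4c3)c2n1` carries a thiophen-3-yl and gives 10%. On the bare numbers compound 2 sits at the bottom of the three, but the step of a number 7.8 percentage points lower from compound 1 to compound 2 (within the scatter) and the step of a number 7.6 percentage points higher from compound 2 to compound 3 (within the scatter) both lie within the scatter, so the three cannot be told apart.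

Compound 4 `c1csc(-c2cn3ccnc3c(-c3ccc4ncn(C5CCCCC5)c4c3)n2)c1` differs from compound 2 by thiophen-2-yl in place of 4-fluorophenyl on an aromatic carbon. The step that bears on this most directly is a number 7.6 percentage points higher from compound 2 to compound 3 (within the scatter), where a closely related thiophene took the same place and changed nothing beyond the scatter; a number 0.2 percentage points lower from compound 1 to compound 3 (within the scatter) points the same way. The step of a number 5.6 percentage points higher from compound 2 to compound 4 (within the scatter) is therefore expected to stay within the scatter. Compound 4 is estimated at 8%, with a range from -2% to 18%.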

Compound 4, a percentage reported as inhibition, at one concentration (the size of the read-out at that concentration, not a potency): 5.95%
Compound 4: the middle estimate sits 2.1 percentage points above what was measured; the range from low to high includes it.
By their numbers in this assay, from the lowest: compounds 2, 4, 3 and 1 (each within the scatter of the next).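

In this assay, moving the attachment on the thiophene from its 3-position to its 2-position gives a number 4.1 percentage points lower from compound 3 to compound 4 (within the scatter), so the two thiophene forms cannot be told apart at this place. Among the compounds shown here, the other two comparisons for the new compound, a number 3.6 percentage points higher from compound 2 to compound 4 (within the scatter) and a number 4.3 percentage points lower from compound 1 to compound 4 (within the scatter), also stay inside the scatter, so bromo, 4-fluorophenyl, thiophen-3-yl and thiophen-2-yl all give numbers that cannot be separated, and no compound here goes against that. Nothing available explains this flat picture.

From the compounds shown here alone, whether a different kind of group on this aromatic carbon, such as an amine or a carboxylic acid, would move the number beyond the scatter remains open. These readings come from a single concentration, so they also leave any difference in potency among the four compounds open.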